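Adding a ring to the acetyl carbonyl

The source may hold more compounds than are shown below. What is called first, only, known or untested is meant among the compounds shown, and "the series" means these compounds.

Measured in a functional assay on MDA-MB-468 cells (Homo sapiens) for antiproliferative activity, read by MTT assay, with a stated time of 48 h; on this read-out higher numbers stand for weaker inhibition and lower numbers for stronger inhibition:
- Compound 1 `CN(C)CCNc1cc2c(cn1)cc(NC(=O)c1cc3ccccc3s1)c(=O)n2C`: 3570 nM
- Compound 2 `CC(=O)Nc1cc2cnc(NCCN(C)C)cc2n(C)c1=O`: > 100000 nM, a limit and not a number
- Compound 3 `COc1ccc(C(=O)Nc2cc3cnc(N4CCN(C)CC4)cc3n(C)c2=O)cc1`: 12600 nM

Compound 2 sits at the limit of > 100000 nM in this assay, at which 1 of the 3 values shown sits, so it has only a limit. Compound 4 `CN(C)CCNc1cc2c(cn1)cc(NC(=O)c1ccncc1)c(=O)n2C` has pyridin-4-yl in place of methyl on a carbonyl carbon. Within the data shown here, one measured step bears on this change: an at least 28-fold higher number from compound 1 to compound 2 (1.44 log units; beyond the scatter). That large step replaced 1-benzothiophen-2-yl with methyl, so putting a ring back should lower the number in this assay, meaning stronger inhibition. Pyridin-4-yl is a different ring, so compound 1 is only a rough guide. A large step is expected: an at least 6.6-fold lower number from compound 2 to compound 4 (0.82 log units; beyond the scatter). For compound 4 the estimated value is 15000 nM, with an expected range of 4000 nM to 60000 nM.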

Compound 4, half-maximal inhibitory concentration: 8360 nM
The estimate for compound 4 lay 1.8-fold (0.25 log units) above the measured number, within the range that was stated.
By their numbers in this assay, from the lowest: compound 1; then compounds 4 and 3 (each within the scatter of the next). At a limit, above all of these: compound 2.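

In this assay a ring on this carbonyl carbon need not be 1-benzothiophen-2-yl to bring the number down: the data show an at least 11-fold lower number from compound 2 to compound 4 (1.07 log units; beyond the scatter) when pyridin-4-yl replaces methyl. The choice of ring still counts, with a 2.3-fold higher number from compound 1 to compound 4 (0.37 log units; beyond the scatter) as a modest step when pyridin-4-yl replaces 1-benzothiophen-2-yl. The first of these steps rests on a limit and not on a number: the limit of > 100000 nM in this assay, at which 1 of the 4 values shown sits.

The compounds shown leave open how plain phenyl, with no ring nitrogen, would compare with pyridin-4-yl here. They also leave open whether a saturated ring such as piperidin-4-yl would lower the number as well.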